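Allyl in place of ethyl on a triazene nitrogen

The source may report more compounds than this note shows. Statements on the series, on what has been measured and on what is new or still open speak of the compounds shown alone.

Measured so far:
Compound 1 `CCN(C)/N=N/c1ccc(NC(N)=O)cc1`: 3.87
Compound 2 `COC(=O)c1ccc(/N=N/N(C)C)cc1`: 3.2
Compound 3 `CCOC(=O)c1ccc(/N=N/N(C)CC)cc1`: 3.01

For the measured compounds named here, in a functional assay on L1210 cells (Mus musculus) for antiproliferative activity (a higher number here means a more potent compound, by a factor of ten per unit of this negative logarithm, a lower number a less potent compound), compound 1 gives the highest of the three numbers; compound 2 sits a number 0.86 log units lower from compound 1 to compound 3 (beyond the scatter), and the single measured step, a number 0.86 log units lower from compound 1 to compound 3 (beyond the scatter), concerns a change on the aromatic ring, not on the amine chain.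

Compound 4 `C=CCN(C)/N=N/c1ccc(NC(N)=O)cc1` differs from compound 1 as follows: vinyl in place of methyl on a saturated chain carbon bound to an amine nitrogen. Going by the values given here, no measured step touches this part of the molecule, so nothing among the measured compounds bears directly on it. A small chain change of this kind is expected to leave the number close to that of compound 1, so the step of a number 0.07 log units lower from compound 1 to compound 4 (within the scatter) is estimated to stay within the scatter. For compound 4 the expected value is 3.8, with a likely range from 3.3 to 4.3.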

Compound 4, logarithm of the reciprocal of the active concentration, log(1/C): 3.77
For compound 4 the middle estimate is 0.03 log units above the measured one; measured number inside the range.
By their numbers in this assay, from the lowest: compounds 3 and 2 (each within the scatter of the next); then compounds 4 and 1 (each within the scatter of the next).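

In this assay, for the compounds shown here, the first measured change on this chain, ethyl to allyl, gives a number 0.10 log units lower from compound 1 to compound 4 (within the scatter), so the two groups cannot be told apart here. The shared core therefore accepts one extra carbon and a double bond outside aromatic rings at this place without a step beyond the scatter. Nothing available explains this result. From the compounds shown here alone, it remains open whether a longer chain such as butyl, or a chain ending in an amine or a carboxylic acid, would also stay within the scatter. Whether allyl behaves the same with ethoxycarbonyl in place of ureido is also unknown.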